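Methoxy for chloro in a pair that shows no cytotoxicity

This account rests on a few compounds, and the source may have more. Where it says the series, first, only, none or still open, it means among the compounds named here.

Compound 1, `COc1ccc(-n2ccc(=O)c(C(=O)Nc3ccc(Oc4ccnc5[nH]ccc45)c(F)c3)n2)cc1`: in a functional assay on HepG2 cells (Homo sapiens) for cytotoxicity, read by MTT assay, with a stated time of 72 h (a lower number here means a stronger inhibitor, a higher number a weaker inhibitor), compound 1 reaches only a limit, > 60000 nM.
Compound 2, `Cn1ccc2c(Oc3ccc(NC(=O)c4nn(-c5ccc(Cl)cc5)ccc4=O)cc3F)ccnc21`: in this assay compound 2 likewise reaches only a limit, > 60000 nM.

Compound 2 therefore stands nowhere on a scale of numbers: its result in this assay is a limit and not a measured concentration. Compound 1 sits at the very same limit. Going by the values given here, the whole picture so far is summed up as the limit of > 60000 nM in this assay, at which 2 of the 2 values shown sit, and because of that the limit of > 60000 nM in this assay, at which 2 of the 2 values shown sit, no step between measured compounds can be computed.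

Compound 3 `COc1ccc(-n2ccc(=O)c(C(=O)Nc3ccc(Oc4ccnc5c4ccn5C)c(F)c3)n2)cc1` differs from compound 2 in one place: methoxy in place of chloro on an aromatic carbon. Compound 1 already carries the methoxyphenyl on a closely related core and still sits at the limit, so nothing in the data suggests that this exchange brings the read-out into the measurable range. Compound 3 is therefore expected to remain at the limit, and the step that the limit leaves unreadable from compound 2 to compound 3 is estimated as none beyond the scatter. Compound 3 is expected to give about 90000 nM, with a range from 40000 nM to 250000 nM.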

Compound 3, half-maximal inhibitory concentration: > 60000 nM
Compound 3 was reported as a limit; the forecaster's own chance of this, stated with the estimate: 85%; the middle value is on the limit's open side.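

No step to compound 3 can be read, from compound 2 or from compound 1, in this assay, as all three results are limits and not numbers: the limit of > 60000 nM in this assay, at which 3 of the 3 values shown sit.

The compounds shown leave open whether methoxy and chloro, or methyl and hydrogen on the aromatic nitrogen, differ at all in this read-out.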